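Fluoro in place of methoxy: compound 3 to compound 4

The source may report more compounds than this note shows. Statements on the series, on what has been measured and on what is new or still open speak of the compounds shown alone.

Measured in a functional assay on MCF7 cells (Homo sapiens) for antiproliferative activity, read by sulforhodamine B assay, with a stated time of 48 h; a lower number here means a stronger inhibitor, a higher number a weaker inhibitor:
Compound 1 `CN1CCN(c2ccc(S(=O)(=O)Oc3ccc(F)cc3)cc2)C1=O`: > 100000 nM, a limit
Compound 2 `CCCN1CCN(c2ccc(S(=O)(=O)Oc3ccccc3C)cc2)C1=O`: > 100000 nM, a limit
Compound 3 `CCCN1CCN(c2ccc(S(=O)(=O)Oc3ccc(OC)cc3)cc2)C1=O`: 20000 nM

Compound 3, at 20000 nM, is the only one of the three with an actual number in this assay. Compound 1 and compound 2 both stand at the limit of > 100000 nM in this assay, at which 2 of the 3 values shown sit.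

Compound 4 `CCCN1CCN(c2ccc(S(=O)(=O)Oc3ccc(F)cc3)cc2)C1=O` keeps the propyl chain and the shared core of compound 3 and differs from it in one place, with fluoro in place of methoxy on an aromatic carbon, para to a large group: fluoro in place of methoxy on an aromatic carbon.

Going by the values given here, only one measured step bears on this change. As far as these compounds go, that step, an at least 5.0-fold lower number from compound 2 to compound 3 (0.69 log units; beyond the scatter), puts 4-methoxyphenyl in place of 2-methylphenyl and lies beyond the scatter, so a change on this ring can move the number, although its full size stays open. Compound 1 carries the same 4-fluorophenyl as compound 4, with methyl in place of propyl. Compound 1 stands at > 100000 nM, a limit.

On this evidence a modest weakening is expected, the estimated change being a 2.0-fold higher number from compound 3 to compound 4 (0.30 log units; within the scatter). A result at the limit would also fit these data. For compound 4 the estimated value is 40000 nM, with an expected range of 10000 nM to 100000 nM.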

Compound 4, half-maximal inhibitory concentration: 33000 nM
Estimate against measurement, compound 4: 1.2-fold (0.08 log units) above; measured number inside the range.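

In this assay, going by these compounds alone, the change on the aromatic carbon para to a large group stays within the scatter (a 1.7-fold higher number from compound 3 to compound 4 (0.22 log units; within the scatter)), so fluoro and methoxy cannot be told apart at this position, something the single number available before could not show. The 4-fluorophenyl group also stands clear of the 2-methylphenyl group (an at least 3.0-fold lower number from compound 2 to compound 4 (0.48 log units; beyond the scatter)), so the earlier step from that group to 4-methoxyphenyl is not particular to methoxy. With 4-fluorophenyl kept, propyl in place of methyl also moves the number beyond the scatter (an at least 3.0-fold lower number from compound 1 to compound 4 (0.48 log units; beyond the scatter)), but these last two steps fix only a minimum size, because compound 1 and compound 2 each rest on a limit rather than a number: the limit of > 100000 nM in this assay, at which 2 of the 4 values shown sit.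

With only methoxy and fluoro compared at this position, the compounds shown leave open whether a hydroxyl, an amine or a carboxylic acid there would move the number beyond the scatter. They also leave open how a chain longer than propyl, such as butyl or hexyl, would read on the shared core.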